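The source may hold more compounds than are shown below. What is called first, only, known or untested is meant among the compounds shown, and "the series" means these compounds.

Of the compounds shown here, three built on the same core have so far been measured in a functional assay on cells (Neutrophil, Homo sapiens) for inhibition, with a stated time of 10 min; on this read-out lower numbers stand for stronger inhibition and higher numbers for weaker inhibition. Compound 1 `CCOC(=O)c1cnn(CC(O)CC)c1NC(=O)Nc1cccc2ccccc12` gives 12 nM in this assay, and compound 3 `CCOC(=O)c1cnn(CC(O)CC)c1NC(=O)Nc1ccccc1F` gives 120 nM. Compound 2 `CCCC(O)Cn1ncc(C(=O)OCC)c1NC(=O)NCc1ccccc1` gives 0.43 nM, the lowest of the three numbers; its nearest neighbour is compound 1 and its furthest is compound 3, and both gaps lie beyond the usual scatter of repeated measurements. Within the data shown here, compound 1 and compound 3 both carry an aryl urea, whereas compound 2 carries a benzyl urea, but no single-change step between measured compounds separates these features, so nothing more than the numbers themselves can be read from that comparison.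

Compound 4 `CCOC(=O)c1cnn(CC(C)O)c1NC(=O)NCc1ccccc1` has not yet been measured. It differs from compound 2 in one place: hydrogen in place of ethyl on a saturated chain carbon, two bonds along the chain from an oxygen on a saturated carbon. Among the measured compounds shown here, no pair of measured compounds shows a change of this kind, so the expectation rests on compound 2 alone. A shorter chain of this sort is expected to cost a little potency, and the expected step is a 3.5-fold higher number from compound 2 to compound 4 (0.54 log units; beyond the scatter), a rise in the number that may still fall within the scatter. Compound 4 is therefore estimated at 1.5 nM, with a range from 0.3 nM to 8 nM.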

Compound 4, half-maximal inhibitory concentration: 15 nM
Compound 4: the middle estimate sits 10-fold (1.00 log units) below what was measured; the whole stated range lies below it.
By their numbers in this assay, from the lowest: compound 2; then compounds 1 and 4 (each within the scatter of the next); then compound 3.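

Among these compounds, the step from 2-hydroxypentyl to 2-hydroxypropyl is the first single-change comparison, and in this assay it is large: a 35-fold higher number from compound 2 to compound 4 (1.54 log units; beyond the scatter). It shows that on this saturated chain carbon, two bonds along the chain from an oxygen on a saturated carbon, ethyl cannot be replaced by hydrogen without a marked rise in the number, even with the benzyl urea and the rest of the molecule unchanged. Nothing at hand explains the size of this step.

The compounds shown leave open whether the rise builds gradually with chain shortening, as an intermediate 2-hydroxybutyl chain could show, and whether a longer chain such as 2-hydroxyhexyl would lower the number further or raise it again. They also leave open whether the same change would have a step of similar size on an aryl urea such as that of compound 1 or compound 3, and whether an amine could stand in place of the hydroxyl on this chain.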